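Fluoro in place of methyl on a weakly cytotoxic acid

The source may report more compounds than this note shows. Statements on the series, on what has been measured and on what is new or still open speak of the compounds shown alone.

Compound 1 `C=C1CC[C@H]2C(C)(C)CCC[C@]2(C)[C@H]1CCC(C)CC(=O)OC`: > 200000 nM
Compound 2 `Cc1ccc(/C=C2\CC[C@H]3C(C)(C)CCC[C@]3(C)[C@H]2CCC(C)CC(=O)O)cc1`: > 200000 nM

Both values come from a functional assay on THP-1 cells (Homo sapiens) for cytotoxicity, read by MTT assay, with a stated time of 24 h; on this read-out lower numbers stand for stronger inhibition and higher numbers for weaker inhibition. For compound 1 the value > 200000 nM is a limit of the assay, not a number. For compound 2 the value > 200000 nM is likewise only a limit. Compound 2 therefore stands at the same limit as the other measured compound (the limit of > 200000 nM in this assay, at which 2 of the 2 values shown sit). Compound 3 `CC(CC[C@H]1/C(=C/c2ccc(F)cc2)CC[C@H]2C(C)(C)CCC[C@]12C)CC(=O)O` differs from compound 2 by fluoro in place of methyl on an aromatic carbon. For the measured compounds named here, no step between measured compounds is known here, so the step of a number no higher from compound 2 to compound 3 (the limit leaves the size open) is expected to stay within the scatter. Compound 3 is estimated at 200000 nM, between 100000 nM and 400000 nM, most likely reported again as a limit.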

Compound 3, half-maximal inhibitory concentration: > 200000 nM
Compound 3 was reported as a limit (the forecaster's own chance of this, stated with the estimate: 80%); the middle value lies on the limit itself.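

For the compounds shown here, compound 2 and compound 3 both stand at a limit rather than a number, so no step between them can be read: the limit of > 200000 nM in this assay, at which 3 of the 3 values shown sit. On these data alone, whether fluoro in place of methyl changes anything at all stays open, as does what would bring a value off that limit.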